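This account rests on a few compounds, and the source may have more. Where it says the series, first, only, none or still open, it means among the compounds named here.

Measured in a functional assay, read by spectrophotometry, with a stated time of 2 h, tested at 2.5 mg/mL; on this read-out lower numbers stand for a weaker effect and higher numbers for a stronger effect at the one concentration tested:

Compound 1 `CC(C)[C@@H]1CC[C@@H](C)C[C@@]12N(C)C(=O)[C@@H]1[C@H]3C(=O)N(c4ccccc4)C(=O)[C@H]3ON12` gives 53.1%
Compound 2 `COc1ccc(N2C(=O)[C@H]3[C@H](ON4[C@@H]3C(=O)N(C)[C@@]43C[C@H](C)CC[C@H]3C(C)C)C2=O)cc1` gives 59.3%
Compound 3 `Cc1cccc(N2C(=O)[C@H]3[C@H](ON4[C@@H]3C(=O)N(C)[C@@]43C[C@H](C)CC[C@H]3C(C)C)C2=O)c1` gives 57.6%

Compound 3 stands second highest of the three numbers, yet both separations are within the scatter: a number 1.7 percentage points lower from compound 2 to compound 3 (within the scatter) and a number 4.5 percentage points higher from compound 1 to compound 3 (within the scatter). Compound 4 `CC(C)[C@@H]1CC[C@@H](C)C[C@@]12N(C)C(=O)[C@@H]1[C@H]3C(=O)N(c4ccc5ccccc5c4)C(=O)[C@H]3ON12` carries one change: naphthalen-2-yl in place of 3-methylphenyl on an amide-type nitrogen in a ring. The step that bears most directly on this is the earlier swap of the group on the same nitrogen, a number 1.7 percentage points lower from compound 2 to compound 3 (within the scatter), and the two substitutions on an aromatic carbon, a number 6.2 percentage points higher from compound 1 to compound 2 (within the scatter) and a number 4.5 percentage points higher from compound 1 to compound 3 (within the scatter), were equally small. No shown step on this position moves this assay beyond the scatter, so compound 4 is expected to give a number 0.6 percentage points lower from compound 3 to compound 4 (within the scatter). Compound 4 is estimated at 57%, within 44% to 70%.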

Compound 4, a percentage reported as activity, at one concentration (the size of the read-out at that concentration, not a potency): 45.1%
Beside the measured number, compound 4's estimate is 11.9 percentage points above it, within the range that was stated.
By their numbers in this assay, from the lowest: compounds 4, 1, 3 and 2 (each within the scatter of the next, the first and the last beyond it).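

For the compounds shown here, this is the first change on the amide-type nitrogen that moves this assay beyond the scatter, so the group held there can matter: naphthalen-2-yl gives a number 12.5 percentage points lower from compound 3 to compound 4 (beyond the scatter) and a number 14.2 percentage points lower from compound 2 to compound 4 (beyond the scatter). Against the plain phenyl, the same swap stays within the scatter (a number 8 percentage points lower from compound 1 to compound 4 (within the scatter)), so the separation holds only against 3-methylphenyl and 4-methoxyphenyl. No available measurement offers a reason for this result.

Still open, from the compounds shown here alone, is how this nitrogen would respond to a group without an aromatic ring, such as cyclohexyl, or to a phenyl carrying an amine or a carboxylic acid.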